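This account rests on a few compounds, and the source may have more. Where it says the series, first, only, none or still open, it means among the compounds named here.

Measured so far, in a functional assay on PC-3 cells (Homo sapiens) for cytotoxicity, read by MTT assay, with a stated time of 48 h; on this read-out lower numbers stand for stronger inhibition and higher numbers for weaker inhibition:

Compound 1, `Cc1ccc(Cn2c(/C=C3\SC(=S)N(CC(=O)O)C3=O)nc3cc(Cl)ccc32)cc1`, gives 26700 nM.
Compound 2, `Cc1ccc(Cn2c(/C=C3\SC(=S)N(CC(=O)O)C3=O)nc3ccc(Cl)cc32)cc1`, gives 1520 nM.
Compound 3, `O=C(O)CN1C(=O)/C(=C/c2nc3cc(Cl)ccc3n2Cc2ccccc2F)SC1=S`, gives 3480 nM.

Compound 1 and compound 2 are built from the same atoms joined differently; how the two cores differ is not broken down here. Compound 2 has the lowest number of the three. Compound 3 arises from compound 1 by one change, (2-fluorophenyl in place of 4-methylphenyl on a saturated chain carbon bound to an aromatic nitrogen), and this change gave a 7.7-fold lower number from compound 1 to compound 3 (0.88 log units; beyond the scatter).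

The unmeasured compound 4, `O=C(O)CN1C(=O)/C(=C/c2nc3ccc(Cl)cc3n2Cc2ccccc2F)SC1=S`, stands to compound 2 as compound 3 stands to compound 1: the change is 2-fluorophenyl in place of 4-methylphenyl on a saturated chain carbon bound to an aromatic nitrogen, at the same place in the printed words. Because compound 2 gives 1520 nM and so already starts from a lower number than compound 1 with 26700 nM, the step in this assay is expected to be smaller than the earlier one of a 7.7-fold lower number from compound 1 to compound 3 (0.88 log units; beyond the scatter), and the expected step from compound 2 to compound 4 is a 3.4-fold lower number from compound 2 to compound 4 (0.53 log units; beyond the scatter). Compound 4 is therefore estimated at 450 nM, with a likely range from 130 nM to 1500 nM.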

Compound 4, half-maximal inhibitory concentration: 17300 nM
Compound 4: middle estimate off by 38-fold (1.58 log units), on the low side; the measured number lies above the stated range.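

In this assay, putting 2-fluorophenyl in place of 4-methylphenyl gave an 11-fold higher number from compound 2 to compound 4 (1.06 log units; beyond the scatter), so the swap that lowered the number on the core of compound 1 raised it on the core of compound 2. The two steps run in opposite directions, so in this series the change cannot be carried from one core to the other as a single fixed effect: the same change on two cores in this assay, a 7.7-fold lower number (0.88 log units; beyond the scatter) from compound 1 to compound 3 and an 11-fold higher number (1.06 log units; beyond the scatter) from compound 2 to compound 4, 87-fold (1.94 log units) apart, beyond the scatter of two such steps

This shows that the outcome of the change depends on the core that carries it, but it does not show why, and two pairs cannot predict what the change would do on a further core.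

The compounds shown leave open whether other groups at this place, such as a plain benzyl or a longer chain such as phenethyl, would also reverse with the core. They also leave open whether the same reversal would hold with a methyl ester or an amide in place of the carboxylic acid.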